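Chloro to fluoro on the terminal phenyl ring

The source may report more compounds than this note shows. Statements on the series, on what has been measured and on what is new or still open speak of the compounds shown alone.

The measured compounds:
Compound 1 `CNC(=O)c1cc(Oc2ccc3nc(NC(=O)c4cccc(F)n4)sc3c2)ccn1` gives 89.4% in a functional assay on SK-BR-3 cells (Homo sapiens) for inhibition, read by MTT assay, with a stated time of 2 days, tested at 100 uM; a higher number here means more inhibition of growth at the concentration tested, a lower number less inhibition of growth.
Compound 2 `CNC(=O)c1cc(Oc2ccc3nc(NC(=O)c4cc(Cl)cc(Cl)c4)sc3c2)ccn1` gives 84.3% in this assay.
Compound 3 `CNC(=O)c1cc(Oc2ccc3nc(NC(=O)Nc4ccc(Cl)cc4)sc3c2)ccn1` gives 77.4% in this assay.

Compound 3 holds the lowest of the three numbers: one step is a number 6.9 percentage points lower from compound 2 to compound 3 (within the scatter), and the other is a number 12 percentage points lower from compound 1 to compound 3 (beyond the scatter). Compound 4 `CNC(=O)c1cc(Oc2ccc3nc(NC(=O)Nc4ccc(F)cc4)sc3c2)ccn1` differs from compound 3 in a single place: fluoro in place of chloro on an aromatic carbon. Within the data shown here, no measured step exchanges one halogen for another on this ring; the closest comparison, a number 5.1 percentage points lower from compound 1 to compound 2 (within the scatter), replaces an entire aromatic group and still stays within the scatter, so a small halogen swap is not expected to move the number much. For compound 4 the expected step is a number 2.4 percentage points lower from compound 3 to compound 4 (within the scatter), none beyond the scatter. Compound 4 is therefore estimated at 75%, within 62% to 87%.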

Compound 4, percent growth inhibition at one concentration: 72.9%
For compound 4 the middle estimate is 2.1 percentage points above the measured one; measured number inside the range.
By their numbers in this assay, from the lowest: compounds 4, 3, 2 and 1 (each within the scatter of the next, the first and the last beyond it).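

Fluoro in place of chloro, on an aromatic carbon para to a large group, gives a number 4.5 percentage points lower from compound 3 to compound 4 (within the scatter) in this assay, so exchanging these two halogens here leaves no readable effect. Even so, compound 4 stands clearly apart from the other acyl groups, with a number 11.4 percentage points lower from compound 2 to compound 4 (beyond the scatter) and a number 16.5 percentage points lower from compound 1 to compound 4 (beyond the scatter), whereas compound 3 stayed within the scatter of compound 2. No measurement here offers an explanation for these steps. Open, going by these compounds, is whether a methoxy group, an amine or a trifluoromethyl group at this position would shift the number beyond the scatter.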